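Swapping a Triazole Tail for Pyrrolidine in Compound 1

This account rests on a few compounds, and the source may have more. Where it says the series, first, only, none or still open, it means among the compounds named here.

Measured so far:
compound 1, `Cn1ncc(Cl)c1-c1cc(C(=O)N[C@@H]2CN[C@H](CCn3cncn3)C[C@H]2c2ccc(Cl)c(Cl)c2)oc1Cl`: 60 nM
compound 2, `CC(=O)OCC[C@@H]1C[C@@H](c2ccc(F)c(F)c2)[C@H](NC(=O)c2cc(-c3c(Cl)cnn3C)c(Cl)o2)CN1`: "not determined" (no result reported)

In a functional assay on LNCaP cells (Homo sapiens) for antiproliferative activity (on this read-out lower numbers stand for stronger inhibition and higher numbers for weaker inhibition), compound 1 gives 60 nM. Within the data shown here, it is the only compound here with a number, so it stands alone, with nothing to compare against. For compound 2 the result is "not determined" (no result reported). Compound 3, `Cn1ncc(Cl)c1-c1cc(C(=O)N[C@@H]2CN[C@H](CCN3CCCC3)C[C@H]2c2ccc(Cl)c(Cl)c2)oc1Cl`, differs from compound 1 in a single place: pyrrolidin-1-yl in place of 1H-1,2,4-triazol-1-yl on a saturated chain carbon, two bonds along the chain from a saturated ring carbon. Among the measured compounds shown here, with no measured pair to show how large such a step tends to be, the change expected from compound 1 to compound 3 is a 1.3-fold higher number from compound 1 to compound 3 (0.12 log units; within the scatter), not beyond the usual scatter. Compound 3 is therefore estimated at 80 nM, within a range from 25 nM to 250 nM.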

Compound 3, half-maximal inhibitory concentration: 1920 nM
Beside the measured number, compound 3's estimate is 24-fold (1.38 log units) below it; measured number above the stated range.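

This chain position is sensitive to the group it carries. In this assay, replacing 1H-1,2,4-triazol-1-yl with pyrrolidin-1-yl gives a 32-fold higher number from compound 1 to compound 3 (1.51 log units; beyond the scatter), even though both groups are five-membered rings with the same number of heavy atoms. No measurement shown here explains this loss of activity.

This single pair cannot separate the effect of losing the aromatic ring from that of losing ring nitrogens. On these data alone, an imidazol-1-yl or morpholin-4-yl group at this position, or a longer chain, remains open.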